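Swapping an Anilide Phenyl for Cyclopentyl in a Quinolone Series

The source may report more compounds than this note shows. Statements on the series, on what has been measured and on what is new or still open speak of the compounds shown alone.

Three compounds share one core and differ at the far end of a side chain. Compound 1 `C#CCn1cc(C(=O)NC(CC(=O)Nc2ccccn2)c2ccccc2)c(=O)c2ccc(Cl)nc21` carries a pyridin-2-yl group on an amide-type nitrogen. In a functional assay on A549 cells (Homo sapiens) for cytotoxicity, read by MTT assay, with a stated time of 72 h (a higher number here means a weaker inhibitor, a lower number a stronger inhibitor), compound 1 gives > 10000 nM, which is a limit of the assay rather than a number. Compound 2 `C#CCn1cc(C(=O)NC(CC(=O)Nc2ccccc2)c2ccccc2)c(=O)c2ccc(Cl)nc21` has phenyl in that position. In this assay compound 2 gives > 10000 nM, again a limit. Compound 3 `C#CCn1cc(C(=O)NC(CC(=O)Nc2ccccc2)c2ccccc2)c(=O)c2cccnc21` drops the chloro for hydrogen on an aromatic carbon. In this assay compound 3 gives > 10000 nM, once more a limit. Both recorded steps, a step that the two limits leave unreadable from compound 1 to compound 2 and a step that the two limits leave unreadable from compound 2 to compound 3, are therefore unreadable in size, because of the limit of > 10000 nM in this assay, at which 3 of the 3 values shown sit.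

Compound 4 `C#CCn1cc(C(=O)NC(CC(=O)NC2CCCC2)c2ccccc2)c(=O)c2ccc(Cl)nc21` differs from compound 2 by cyclopentyl in place of phenyl on an amide-type nitrogen. Among the compounds with values here, no measured step bears on this change, and compound 2 itself stands only at a limit, so no direction can be read. Compound 4 is therefore expected to give about 15000 nM, within 7000 nM to 50000 nM, and the step from compound 2 to compound 4 is estimated at a step that the limit leaves unreadable from compound 2 to compound 4, most likely again reported only as a limit.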

Compound 4, half-maximal inhibitory concentration: 9500 nM
The estimate for compound 4 lay 1.6-fold (0.20 log units) above the measured number; the range from low to high includes it.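

Within the data shown here, with cyclopentyl on the amide-type nitrogen, the series gives its only reading in this assay that is a number rather than a limit, which places compound 4 within the measurable range of this assay. Against the phenyl compound the change reads as an at least 1.0-fold lower number from compound 2 to compound 4 (0.02 log units; that floor lies within the scatter), and against the pyridin-2-yl compound it reads as an at least 1.0-fold lower number from compound 1 to compound 4 (0.02 log units; that floor lies within the scatter). These floors therefore show no real gain, and the true distance of compound 4 from either neighbour, like the earlier steps among the other three compounds, cannot be read: the limit of > 10000 nM in this assay, at which 3 of the 4 values shown sit.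

The compounds shown leave open whether the number moves further with a cyclohexyl ring or an open butyl chain in this position. They also leave open whether an amine on the cyclopentyl ring would shift the reading, and what hydrogen in place of chloro does when cyclopentyl is present.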